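This account rests on a few compounds, and the source may have more. Where it says the series, first, only, none or still open, it means among the compounds named here.

Working notes on the series. In a functional assay on HCT-116 cells (Homo sapiens) for antiproliferative activity, read by MTT assay, with a stated time of 72 h (on this read-out lower numbers stand for stronger inhibition and higher numbers for weaker inhibition), compound 1 (`O=C(CCc1cccc2c1B(O)OC2)Nc1cccc(I)c1`) gives 2300 nM, compound 2 (`CC(C)c1cccc(NC(=O)CCc2cccc3c2B(O)OC3)c1`) gives 1600 nM and compound 3 (`O=C(CCc1cccc2c1B(O)OC2)Nc1cccc(-c2ccccc2)c1`) gives 890 nM. Compound 3 carries the lowest number of the three, but it separates clearly only from compound 1, since a 1.8-fold lower number from compound 2 to compound 3 (0.25 log units; within the scatter).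

Compound 4 (`O=C(CCc1cccc2c1B(O)OC2)Nc1cccc(-c2cccc(F)c2)c1`) differs from compound 3 by fluoro in place of hydrogen on an aromatic carbon, which turns phenyl into 3-fluorophenyl. Among the compounds with values here, no measured compound carries fluoro, so the evidence is indirect. The three measured steps each exchange one group on an aromatic carbon: a 1.4-fold lower number from compound 1 to compound 2 (0.16 log units; within the scatter), a 2.6-fold lower number from compound 1 to compound 3 (0.41 log units; beyond the scatter) and a 1.8-fold lower number from compound 2 to compound 3 (0.25 log units; within the scatter). Only the second lies beyond the scatter, and it is modest. Even the exchange of iodo for phenyl therefore moved the number little, and no step beyond the scatter is expected in this assay for fluoro in place of hydrogen. The expected change is a 1.1-fold lower number from compound 3 to compound 4 (0.05 log units; within the scatter), and no direction is firmly expected. For compound 4 the estimated value is 800 nM, with an expected range of 400 nM to 1600 nM.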

Compound 4, half-maximal inhibitory concentration: 460 nM
Beside the measured number, compound 4's estimate is 1.7-fold (0.24 log units) above it, and the stated range covers the measured number.
By their numbers in this assay, from the lowest: compounds 4, 3, 2 and 1 (each within the scatter of the next, the first and the last beyond it).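

In this assay fluoro in place of hydrogen on the phenyl group gives a 1.9-fold lower number from compound 3 to compound 4 (0.29 log units; within the scatter) and so does not by itself separate the pair. Within the data shown here, the change does widen the distance from the other groups on the parent aromatic carbon: 3-fluorophenyl gives a 3.5-fold lower number from compound 2 to compound 4 (0.54 log units; beyond the scatter) where phenyl stayed within the scatter of isopropyl, and against iodo it gives a 5.0-fold lower number from compound 1 to compound 4 (0.70 log units; beyond the scatter) as the largest step so far. No measurement at hand accounts for this result.

From the compounds shown here alone, whether chloro, methoxy or nitrile at this same place on the phenyl group would give a step beyond the scatter from compound 3 remains open. Also open, going by these compounds, is whether an amine or a carboxylic acid would be accepted there.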